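Toward compound 4: side-chain change on the carbonyl carbon

A few compounds are considered here, and "the series" means these few. Any claim that something is new, unique, unknown or untested is made for them only; others in the source may bear on it.

Measured in an ADME assay on CEM-SS cells (Homo sapiens) for cytotoxicity, read by XTT assay, with a stated time of 6 days; on this read-out higher numbers stand for lower toxicity in this test and lower numbers for higher toxicity in this test:
- compound 1 `CCCC(=O)OCSc1ccccc1C(=O)NCCC(N)=O`: > 100 uM (a limit of the assay, not a number)
- compound 2 `CCCC(=O)OCSc1ccccc1C(=O)NCCCCC(N)=O`: 51.7 uM
- compound 3 `CCCC(=O)OCSc1ccccc1C(=O)NCCCCNC(C)=O`: 17.4 uM

Compound 2 holds the higher of the two true numbers. The gap to the nearest number is a 3.0-fold lower number from compound 2 to compound 3 (0.47 log units; beyond the scatter).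

The next structure is compound 4 `CCCC(=O)OCSc1ccccc1C(=O)OCC(N)=O`, and the change is carbamoylmethoxy in place of (4-carbamoylbutyl)amino on a carbonyl carbon. Among the measured compounds shown here, no measured step covers this exchange directly, so the evidence is indirect. Compound 1 carries carbamoyl where compound 2 carries 2-carbamoylethyl on a saturated chain carbon, and that comparison gives an at least 1.9-fold lower number from compound 1 to compound 2 (0.28 log units; that floor lies within the scatter). This floor lies within the scatter, so it sets no firm size. The other comparison with compound 1 gives an at least 5.7-fold lower number from compound 1 to compound 3 (0.75 log units; beyond the scatter), which is beyond the scatter but involves a different terminal group. Compound 4 keeps the terminal carbamoyl and brings in the smaller group, so it more closely resembles compound 1, though its link to the carbonyl differs from that of every measured compound.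

A modest move to a higher number is expected in this assay, with the estimated change being a 1.5-fold higher number from compound 2 to compound 4 (0.16 log units; within the scatter). For compound 4 the expected value is 75 uM, with an estimated range of 28 uM to 150 uM.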

Compound 4, half-maximal toxic concentration: 82.1 uM
The estimate for compound 4 lay 1.1-fold (0.04 log units) below the measured number, and the stated range covers the measured number.
By their numbers in this assay, from the lowest: compound 3; then compounds 2 and 4 (each within the scatter of the next). At a limit, above all of these: compound 1.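

Notes on the position: on a carbonyl carbon whose other neighbour is an aromatic carbon, compound 4 is the only compound shown with an oxygen-linked group, carbamoylmethoxy, rather than a nitrogen-linked one. In this assay, among the compounds shown here, replacing (4-carbamoylbutyl)amino with carbamoylmethoxy gives a 1.6-fold higher number from compound 2 to compound 4 (0.20 log units; within the scatter), so this exchange of both link and chain produces no step that can be told from the scatter. Against the (2-carbamoylethyl)amino group, the exchange gives an at least 1.2-fold lower number from compound 1 to compound 4 (0.08 log units; that floor lies within the scatter), and this floor gives no firm size or direction for the step. Compound 1 gives > 100 uM, which is a limit and not a number: the limit of > 100 uM in this assay, at which 1 of the 4 values shown sits.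

Still open, on these data alone, is how the link atom and the chain length each contribute, as the step from compound 2 changes both at once, and any opposing contributions could cancel in this single reading. A carbamoylmethylamino group or a longer oxygen-linked chain ending in carbamoyl would separate the two, while a carboxylic acid or an amine at the chain end would test how much the terminal carbamoyl matters on the oxygen-linked side.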